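Ester side-chain change in a dihydropyridine calcium-channel series

The compounds below may be only part of what the source reports. "The series", "measured", "known", "first", "only" and "open" are said of these compounds alone.

Measured so far:
compound 1 `CC1=NC(C)=C(C(=O)O)C(c2ccccc2[N+](=O)[O-])/C1=C(\O)OC/C=C/c1ccccc1` gives 37000 nM;
compound 2 `CC1=NC(C)=C(C(=O)O)C(c2cccc(I)c2)/C1=C(\O)OC/C=C/c1ccccc1` gives 1700 nM;
compound 3 `CC1=NC(C)=C(C(=O)O)C(c2cccc(Cl)c2)/C1=C(\O)OC/C=C/C1CCCCC1` gives 830 nM.

All three numbers come from a functional assay on IMR-32 cells for inhibition of Voltage-dependent N-type calcium channel subunit alpha-1B (Homo sapiens), read by calcium flux; on this read-out higher numbers stand for weaker inhibition and lower numbers for stronger inhibition. Compound 3 stands lowest of the three numbers, with compound 2 nearest and compound 1 furthest. Going by the values given here, the one step measured so far within one change, a 22-fold lower number from compound 1 to compound 2 (1.34 log units; beyond the scatter), concerns the aryl group on the saturated ring carbon, which is held as 3-chlorophenyl in compound 3 and in the new compound.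

Compound 4 `CC1=NC(C)=C(C(=O)O)C(c2cccc(Cl)c2)/C1=C(\O)OCC(=O)Nc1ccccc1` differs from compound 3 in the ester side chain only: phenylcarbamoyl in place of 2-cyclohexylethenyl on a saturated chain carbon bound to an oxygen on an unsaturated carbon. Among the compounds with values here, no measured step touches this part of the structure, so nothing in the numbers so far tells how wide a move to expect in this assay , nor in which direction. The working expectation for compound 4 is a modest move, estimated as a 1.8-fold higher number from compound 3 to compound 4 (0.26 log units; within the scatter), giving an estimated value of 1500 nM with a range from 400 nM to 6000 nM.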

Compound 4, half-maximal inhibitory concentration: 28000 nM
Compound 4: middle estimate off by 19-fold (1.27 log units), on the low side; measured number above the stated range.
By their numbers in this assay, from the lowest: compound 3; then compound 2; then compounds 4 and 1 (each within the scatter of the next).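

With the 3-chlorophenyl group held, phenylcarbamoyl in place of 2-cyclohexylethenyl gives a 34-fold higher number from compound 3 to compound 4 (1.53 log units; beyond the scatter) in this assay. Going by these compounds alone, this is the first measured step at this place, and it shows that the ester side chain alone can move the number widely, here toward weaker inhibition. The entering group differs from the leaving one in its aromatic ring, its hydrogen-bond donor and its hydrogen-bond acceptor, and no evidence at hand accounts for the size of the step.

A single step cannot separate those differences. From the compounds shown here alone, it stays open whether a cyclohexylcarbamoyl group, which keeps the amide and exchanges only the ring, would give a number closer to that of compound 3 or that of compound 4.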